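The source may report more compounds than this note shows. Statements on the series, on what has been measured and on what is new or still open speak of the compounds shown alone.

Working notes, series in a functional assay on RAW264.7 cells (Mus musculus) for inhibition, read by Griess assay, with stated times of 2 h and 24 h; on this read-out lower numbers stand for stronger inhibition and higher numbers for weaker inhibition:

Compound 1 `COc1ccc([C@@H]2CC(=O)c3c(O)cc(OCc4cn(Cc5ccccc5)nn4)cc3O2)cc1O` gives 11000 nM.
Compound 2 `COc1ccc([C@@H]2CC(=O)c3c(O)cc(OCc4cn(CC5CC5)nn4)cc3O2)cc1O` gives 11900 nM.
Compound 3 `COc1ccc([C@@H]2CC(=O)c3c(O)cc(OCc4cn(Cc5cccc(C)c5)nn4)cc3O2)cc1O` gives 17400 nM.

Compound 3 holds the highest of the three numbers, but its distance to compound 2 and to compound 1 is within the scatter, so the three read as one level. The steps that touch the group on the saturated chain carbon bound to the aromatic nitrogen are all flat: a 1.1-fold higher number from compound 1 to compound 2 (0.03 log units; within the scatter), a 1.6-fold higher number from compound 1 to compound 3 (0.20 log units; within the scatter), a 1.5-fold higher number from compound 2 to compound 3 (0.17 log units; within the scatter). Phenyl, cyclopropyl and 3-methylphenyl at that position thus give the same number within noise.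

Compound 4 `COc1ccc([C@@H]2CC(=O)c3c(O)cc(OCc4cn(Cc5ccccc5C)nn4)cc3O2)cc1O` differs from compound 3 as follows: 2-methylphenyl in place of 3-methylphenyl on a saturated chain carbon bound to an aromatic nitrogen. For the measured compounds named here, the group leaving and the group entering are the same atoms joined differently, and no step among the measured compounds at this position has moved the number beyond the scatter. The expected change is therefore none beyond the scatter, with the step estimated as a 1.2-fold lower number from compound 3 to compound 4 (0.06 log units; within the scatter). Compound 4 is expected to give 15000 nM, with a range of 7000 nM to 32000 nM.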

Compound 4, half-maximal inhibitory concentration: 13100 nM
Beside the measured number, compound 4's estimate is 1.1-fold (0.06 log units) above it; low and high end bracket the measured number.
By their numbers in this assay, from the lowest: compounds 1, 2, 4 and 3 (each within the scatter of the next).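

For the compounds shown here, replacing 3-methylphenyl with 2-methylphenyl, the same atoms joined differently, is the first step at this position to test where the methyl sits on the ring, and in this assay that placement does not move the number beyond the scatter (a 1.3-fold lower number from compound 3 to compound 4 (0.12 log units; within the scatter)). Methyl in place of hydrogen on an aromatic carbon also stays within the scatter in this second placement (a 1.2-fold higher number from compound 1 to compound 4 (0.08 log units; within the scatter)), as does 2-methylphenyl in place of cyclopropyl (a 1.1-fold higher number from compound 2 to compound 4 (0.04 log units; within the scatter)). No supporting data bear on this result.

On these data alone, all four groups at this position are built from carbon and hydrogen only, so the effect of an amine, a carboxylic acid or a longer chain such as n-hexyl remains open. The compounds shown also leave open whether a change to the shared core would move the number beyond the scatter.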